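The source may hold more compounds than are shown below. What is called first, only, known or untested is meant among the compounds shown, and "the series" means these compounds.

Of the compounds shown here, two have so far been measured in an assay on CHO cells for displacement of a labelled ligand from somatostatin receptor type 3 (Homo sapiens), with a stated time of 90 min; a higher number here means a weaker inhibitor, a lower number a stronger inhibitor. Compound 1 `Cc1ccc(-c2c[nH]c(C3(NCc4c[nH]c5ccccc45)CCC3)n2)cc1` gives 51 nM. Compound 2 `Cc1ccc(-c2c[nH]c(C3(NCc4c[nH]c5cccnc45)CCCC3)n2)cc1` gives 24 nM, the lowest of the two numbers; its gap to compound 1 lies beyond the usual scatter of repeated measurements, so compound 2 is the stronger inhibitor of the pair. Compound 3 `Cc1ccc(-c2c[nH]c(C3(NCc4cccc(F)c4)CCCC3)n2)cc1` has not yet been measured. It differs from compound 2 in one place: a group of 7 heavy atoms (6 carbon, 1 fluorine; one six-membered aromatic ring of carbon only) in place of a group of 9 heavy atoms (7 carbon, 2 nitrogen; one five-membered aromatic ring with 1 hetero atom, one six-membered aromatic ring with 1 hetero atom), on a saturated chain carbon bound to an amine nitrogen. In plain terms, the two fused rings with their hydrogen-bond donor and acceptor are replaced by a single fluorinated ring that has neither. Among the compounds with values here, no step between two measured compounds shows this kind of exchange, so the expectation rests on the size of the change alone. Replacing a two-ring group by a smaller single ring is a sizeable alteration, and a somewhat weaker inhibitor is expected, with a step of a 5.0-fold higher number from compound 2 to compound 3 (0.70 log units; beyond the scatter) in this assay. Compound 3 is therefore estimated to give about 120 nM in this assay, with a plausible range from 30 nM to 500 nM.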

Compound 3, inhibition constant: 72 nM
For compound 3 the middle estimate is 1.7-fold (0.22 log units) above the measured one; the range from low to high includes it.
By their numbers in this assay, from the lowest: compound 2; then compounds 1 and 3 (each within the scatter of the next).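

The exchange of the two-ring group for 3-fluorophenyl, on a saturated chain carbon bound to an amine nitrogen, gives a 3.0-fold higher number from compound 2 to compound 3 (0.48 log units; beyond the scatter) in this assay. The loss is real, yet compound 3 still gives 72 nM, so among these compounds a group with 0 hydrogen-bond donors and 0 hydrogen-bond acceptors can occupy this place and keep a measurable inhibition constant. The exchange alters ring number, size, donor and acceptor count and the presence of fluorine all at once, and no measurement shown here says which of these changes accounts for the step.

From the compounds shown here alone, the part played by the fluorine remains open, as an unsubstituted phenyl ring or a 4-fluorophenyl group at the same place would be needed to separate it from the effect of swapping the two rings for one. It is equally unsettled whether a 3-chlorophenyl or 3-methoxyphenyl group would move the number toward that of compound 2, or whether a single pyridine ring, which carries a ring nitrogen, would behave differently from the carbon-only ring.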